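Dichlorophenyl to methylphenyl on the ketone of an acrylamide

The source may hold more compounds than are shown below. What is called first, only, known or untested is meant among the compounds shown, and "the series" means these compounds.

Compound 1 `C=C(Br)C(=O)Nc1ccc(/C=C/C(=O)c2ccc(F)cc2)cc1` gives 1200 nM in a functional assay on FM3A cells (Mus musculus) for antiproliferative activity, with a stated time of 48 h; on this read-out lower numbers stand for stronger inhibition and higher numbers for weaker inhibition.
Compound 2 `C=C(Br)C(=O)Nc1ccc(/C=C/C(=O)c2ccc(Cl)cc2)cc1` gives 1300 nM.
Compound 3 `C=C(Br)C(=O)Nc1ccc(/C=C/C(=O)c2ccc(Cl)c(Cl)c2)cc1` gives 3200 nM.

Among these three numbers compound 3 stands highest. Its nearest neighbour is compound 2, and compound 1 lies furthest from it; both gaps are beyond the usual scatter, so compound 3 is the weakest of the measured set on this read-out.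

Compound 4 `C=C(Br)C(=O)Nc1ccc(/C=C/C(=O)c2ccc(C)cc2)cc1` is the next member, and it has not yet been measured. It differs from compound 3 in one place: 4-methylphenyl in place of 3,4-dichlorophenyl on a carbonyl carbon. Among the compounds with values here, two measured steps bear on this change. The step of a 2.5-fold higher number from compound 2 to compound 3 (0.39 log units; beyond the scatter) and the step of a 2.7-fold higher number from compound 1 to compound 3 (0.43 log units; beyond the scatter) both show that arriving at the 3,4-dichlorophenyl ring raised the number modestly, whereas the step of a 1.1-fold higher number from compound 1 to compound 2 (0.03 log units; within the scatter) shows that two rings each carrying a single substituent on that carbonyl carbon gave numbers within the scatter of each other. Compound 4 returns to a ring with a single substituent, so a modest drop, roughly undoing the rise seen on the way to compound 3, is expected.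

Compound 4 is therefore estimated at 1400 nM, with a range from 700 nM to 2800 nM. This estimate means an expected step of a 2.3-fold lower number from compound 3 to compound 4 (0.36 log units; beyond the scatter).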

Compound 4, half-maximal inhibitory concentration: 2100 nM
Compound 4: middle estimate off by 1.5-fold (0.18 log units), on the low side; the range from low to high includes it.
By their numbers in this assay, from the lowest: compounds 1, 2, 4 and 3 (each within the scatter of the next, the first and the last beyond it).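

In this assay the 4-methylphenyl ring on the carbonyl carbon leaves compound 4 within the scatter of all three earlier compounds, with a 1.5-fold lower number from compound 3 to compound 4 (0.18 log units; within the scatter) and a 1.6-fold higher number from compound 2 to compound 4 (0.21 log units; within the scatter) and a 1.8-fold higher number from compound 1 to compound 4 (0.24 log units; within the scatter) as its steps. The earlier compounds shown here had set the 3,4-dichlorophenyl ring of compound 3 apart from the 4-fluorophenyl and 4-chlorophenyl rings, but the methyl-bearing ring cannot be separated from either side, so this change does not show that leaving the 3,4-dichlorophenyl ring restores the lower numbers of compound 1 and compound 2. Methyl can also stand in place of chloro or fluoro on the aromatic carbon with no difference beyond the scatter, although no explanation for these numbers is available here.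

The compounds shown leave open how this position would respond to a ring carrying a methoxy group, an amine or a carboxylic acid in place of the halogen or methyl. They also leave open whether a 3,4-dimethylphenyl ring would stand apart from the 4-methylphenyl ring of compound 4 in the way the 3,4-dichlorophenyl ring stands apart from the 4-chlorophenyl ring.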